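Removing a Methyl from an Aromatic Oxygen on Two Cores

A few compounds are considered here, and "the series" means these few. Any claim that something is new, unique, unknown or untested is made for them only; others in the source may bear on it.

Compound 1 `COc1cc(-c2nn(-c3cccc(NC(=O)Nc4cc(C(F)(F)F)cc(C(F)(F)F)c4)c3)cc2-c2ccncc2)ccc1Cl` and compound 2 `O=C(Nc1cccc(-n2cc(-c3ccncc3)c(-c3ccc(Cl)c(O)c3)n2)c1)Nc1cc(C(F)(F)F)cc(C(F)(F)F)c1` share a core and differ in one spot: hydrogen in place of methyl on an oxygen on an aromatic ring. In a functional assay on T47D cells (Homo sapiens) for inhibition, read by sulforhodamine B assay, with a stated time of 48 h (a higher number here means a weaker inhibitor of growth, a lower number a stronger inhibitor of growth), compound 1 gives 1550 nM, and in the same test compound 2 gives 1820 nM, so the change made a 1.2-fold higher number from compound 1 to compound 2 (0.07 log units; within the scatter). Compound 3 `COc1cc(-c2nn(-c3cccc(NC(=O)Nc4ccc(Cl)c(C(F)(F)F)c4)c3)cc2-c2ccncc2)ccc1Cl` carries the same methoxy group on a core whose difference from the core of compound 1 is not broken down here; in this assay compound 3 gives 1230 nM. Compound 4 `O=C(Nc1cccc(-n2cc(-c3ccncc3)c(-c3ccc(Cl)c(O)c3)n2)c1)Nc1ccc(Cl)c(C(F)(F)F)c1` repeats the change on compound 3: hydrogen in place of methyl on an oxygen on an aromatic ring. For compound 4 the expected step is a 1.2-fold higher number from compound 3 to compound 4 (0.07 log units; within the scatter), because the earlier step was a 1.2-fold higher number from compound 1 to compound 2 (0.07 log units; within the scatter). Compound 4 is thus expected to give about 1450 nM in this assay, most likely between 700 nM and 3000 nM.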

Compound 4, concentration for 50% growth inhibition: 1120 nM
Beside the measured number, compound 4's estimate is 1.3-fold (0.11 log units) above it, and the stated range covers the measured number.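

In this assay, replacing methoxy with hydroxy on compound 3 gives a 1.1-fold lower number from compound 3 to compound 4 (0.04 log units; within the scatter), and this agrees with what the same change does on the core of compound 1: the same change on two cores in this assay, a 1.2-fold higher number (0.07 log units; within the scatter) from compound 1 to compound 2 and a 1.1-fold lower number (0.04 log units; within the scatter) from compound 3 to compound 4, 1.3-fold (0.11 log units) apart, within the scatter of two such steps

On these two cores, then, the swap carries over in the simple sense that neither pair of compounds can be told apart in this test. This does not show that the change has no effect at all, since a small one could hide in the scatter, and two pairs say nothing firm about other cores in the series.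

The compounds shown leave open whether an amine or a longer chain such as ethoxy, put in place of the methoxy, would behave the same way. They also leave open whether a carboxylic acid there would shift the number.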